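Moving the Chloro Substituent on the Shared Core

The compounds below may be only part of what the source reports. "The series", "measured", "known", "first", "only" and "open" are said of these compounds alone.

Compound 1 `C[C@H]([C@H](C(=O)Nc1cccc(CC2(C(=O)O)CC2)c1)c1ccc(Cl)cc1)C(F)(F)F` gives 4% in an assay on CHO cells for activation of Guanylate cyclase soluble subunit alpha-1 (Rattus norvegicus), read by luminescence and cGMP accumulation, with a stated time of 6 min (a lower number here means a smaller maximal response, a higher number a larger maximal response), the lowest of the two numbers measured. Compound 2 `C[C@H]([C@H](C(=O)Nc1cccc(CC2(C(=O)O)CC2)c1Cl)c1ccc(Cl)cc1)C(F)(F)F` carries a chloro in place of hydrogen on an aromatic carbon and gives 19%; the step of a number 15 percentage points higher from compound 1 to compound 2 (beyond the scatter) is modest but beyond the scatter. Compound 3 `C[C@H]([C@H](C(=O)Nc1cc(CC2(C(=O)O)CC2)ccc1Cl)c1ccc(Cl)cc1)C(F)(F)F` differs from compound 1 by chloro in place of hydrogen on an aromatic carbon. Going by the values given here, the only step that bears on it is the one from compound 1 to compound 2, since both add a chloro to the shared core, though at different places. For compound 3 a similar modest rise is expected, a number 8 percentage points higher from compound 1 to compound 3 (within the scatter). Compound 3 is therefore estimated at 12%, with a range from 0% to 30%.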

Compound 3, largest response reached (reported as efficacy), in percent of the reference or control that the assay uses: 63%
Estimate against measurement, compound 3: 51 percentage points below; the whole stated range lies below it.
By their numbers in this assay, from the lowest: compound 1; then compound 2; then compound 3.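

In this assay the exchange of hydrogen for chloro, placed para to the (1-carboxycyclopropyl)methyl group and ortho to a large group, gives a number 59 percentage points higher from compound 1 to compound 3 (beyond the scatter) and so a large step, whereas the other chloro placement gives the modest a number 15 percentage points higher from compound 1 to compound 2 (beyond the scatter) on the same core. The same exchange therefore does not carry one size of effect across the shared core, and its place decides how far the response moves. Nothing available here accounts for this difference. From the compounds shown here alone, whether fluoro, methyl or methoxy at this place would raise the response as chloro does remains open. So does whether a second chloro, at the place used in compound 2, would add to the step.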